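The compounds below may be only part of what the source reports. "The series", "measured", "known", "first", "only" and "open" are said of these compounds alone.

Of the compounds shown here, two from this series have been measured in a functional assay on A549 cells (Homo sapiens) for antiproliferative activity, read by sulforhodamine B assay, with a stated time of 72 h; on this read-out lower numbers stand for stronger inhibition and higher numbers for weaker inhibition. Compound 1, whose structure is `CCCCS(=O)(=O)Nc1cc(-c2ccc3ncnc(Nc4ccc(OCCO)nc4)c3c2)cnc1OC`, gives 13300 nM. Compound 2, whose structure is `COc1ncc(-c2ccc3ncnc(Nc4ccc(OCCO)c(F)c4)c3c2)cc1NS(=O)(=O)c1ccc(F)cc1F`, gives 6640 nM. Of the two numbers, that of compound 2 is the lower, but the gap to compound 1 is within the scatter of repeated measurements, so the two cannot be ranked against each other.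

Compound 3, whose structure is `COc1ncc(-c2ccc3ncnc(Nc4cnn(CCCO)c4)c3c2)cc1NS(=O)(=O)c1ccc(F)cc1F`, has not yet been measured. It differs from compound 2 in one place: 1-(3-hydroxypropyl)-1H-pyrazol-4-yl in place of 3-fluoro-4-(2-hydroxyethoxy)phenyl on a nitrogen on an aromatic ring. The rest of the molecule, including the sulfonamide-bearing side and the shared core, is unchanged.

Going by the values given here, no measured pair shows what such a swap does, so the expectation rests only on compound 2 and the size of the change. A modest shift in the weaker direction, of the order of the scatter itself or a little beyond it, is the expectation for the step of a 1.4-fold higher number from compound 2 to compound 3 (0.13 log units; within the scatter). Compound 3 is therefore estimated to give 9000 nM in this assay, with a likely range from 3000 nM to 27000 nM.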

Compound 3, half-maximal inhibitory concentration: 4830 nM
For compound 3 the middle estimate is 1.9-fold (0.27 log units) above the measured one, and the stated range covers the measured number.
By their numbers in this assay, from the lowest: compounds 3, 2 and 1 (each within the scatter of the next, the first and the last beyond it).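

In this assay, putting 1-(3-hydroxypropyl)-1H-pyrazol-4-yl in place of 3-fluoro-4-(2-hydroxyethoxy)phenyl on a nitrogen on an aromatic ring gives a 1.4-fold lower number from compound 2 to compound 3 (0.14 log units; within the scatter), so compound 2 and compound 3 cannot be ranked against each other. Going by these compounds alone, this is the first direct reading at this position, and it shows that a large change in the group there, from a six-membered aromatic ring of carbon only to a five-membered aromatic ring with 2 hetero atoms and with the fluorine gone, does not move the number beyond the scatter. Nothing else measured on these compounds bears on this result, so it remains an observation without an explanation.

The swap alters the ring, the fluorine and the hydroxyl-bearing chain all at once, so this single pair cannot separate what each of them contributes. Going by these compounds, whether an amine or a carboxylic acid in place of the hydroxyl, or a chain longer than 3-hydroxypropyl, would take the number beyond the scatter also remains open.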